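The compounds below may be only part of what the source reports. "The series", "measured", "known", "first", "only" and "open" are said of these compounds alone.

Measured in a physicochemical assay for solubility, in phosphate buffer, with a stated time of 18 h; on this read-out lower numbers stand for lower solubility and higher numbers for higher solubility:
- Compound 1 `Cc1nc(C(C)(C)C)nc2nc(N)c(C#N)c(N)c12`: 37000 nM
- Compound 2 `CC(C)(C)c1nc(-c2nccs2)c2c(N)c(C#N)c(N)nc2n1`: < 1500 nM (a limit)
- Compound 3 `CC(C)(C)c1nc(-c2ccccc2)c2c(N)c(C#N)c(N)nc2n1`: 4000 nM

Compound 3 has the lower of the two exact numbers in the set, and the gap to compound 1 is large enough to matter: a 9.3-fold lower number from compound 1 to compound 3 (0.97 log units; beyond the scatter). Compound 2 gives only a limit. Against that limit, the comparison reads an at least 2.6-fold higher number from compound 2 to compound 3 (0.42 log units; beyond the scatter).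

Compound 4 `Cc1c[nH]c(-c2nc(C(C)(C)C)nc3nc(N)c(C#N)c(N)c23)n1` carries 4-methyl-1H-imidazol-2-yl in place of phenyl on an aromatic carbon. All three measured steps fall at this same place. Ring groups in place of methyl gave lower numbers both times: an at least 24-fold lower number from compound 1 to compound 2 (1.39 log units; beyond the scatter), alongside the phenyl step already noted. Among the measured compounds shown here, the exchange of one ring group for another is the closest precedent, and there phenyl gave the higher number. For the measured compounds named here, no measured step covers this imidazolyl group, so the expectation is loose: no step clearly beyond the scatter, with a slight lean towards a lower number in this assay. A reported limit is also possible for compound 4.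

The estimated step is a 1.3-fold lower number from compound 3 to compound 4 (0.12 log units; within the scatter). Compound 4 is expected at 3000 nM, with an estimated range of 1200 nM to 10000 nM.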

Compound 4, solubility: 5000 nM
Estimate against measurement, compound 4: 1.7-fold (0.22 log units) below; the measured number falls inside the stated range.
By their numbers in this assay, from the lowest: compounds 3 and 4 (each within the scatter of the next); then compound 1. At a limit, below all of these: compound 2.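

In this assay, the exchange of phenyl for 4-methyl-1H-imidazol-2-yl at this position leaves the two compounds within the scatter of each other (a 1.3-fold higher number from compound 3 to compound 4 (0.10 log units; within the scatter)), even though the entering group carries a hydrogen-bond donor and a hydrogen-bond acceptor where phenyl has neither. Against methyl, the imidazolyl group gives a third case in which a ring group on this aromatic carbon sits under the methyl compound (a 7.4-fold lower number from compound 1 to compound 4 (0.87 log units; beyond the scatter)); compounds 2 and 3 show the same direction, and no compound shown goes against it. The exchange of 1,3-thiazol-2-yl for the imidazolyl group also lies beyond the scatter (an at least 3.3-fold higher number from compound 2 to compound 4 (0.52 log units; beyond the scatter)), but compound 2 gives no exact number, only a limit: the limit of < 1500 nM in this assay, at which 1 of the 4 values shown sits.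

On these data alone, whether this position tolerates other groups at the level of compounds 3 and 4, or returns towards compound 1, stays open for an ethyl chain, an amine or a carboxylic acid. All the compounds shown keep the tert-butyl group, so what a smaller chain such as isopropyl would do to these numbers also remains open.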